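Aryl in Place of Acetyl: Expected Cytotoxicity of Compound 4

The source may hold more compounds than are shown below. What is called first, only, known or untested is meant among the compounds shown, and "the series" means these compounds.

Compound 1, `CC(=O)c1cc2ccc(OCCCn3cc(CNC(=O)CCCCC4CCSS4)nn3)cc2oc1=O`, gives 39.8% in a functional assay on PC-12 cells (Rattus norvegicus) for cytotoxicity, read by MTT assay, with stated times of 3 h and 2 h, tested at 20 uM; a lower number here means a weaker effect, a higher number a stronger effect of the compound at the concentration tested.
Compound 2, `CCOC(=O)c1cc2ccc(OCCCn3cc(CNC(=O)CCCCC4CCSS4)nn3)cc2oc1=O`, gives 42.1% in this assay.
Compound 3, `COc1ccc(-c2cc3ccc(OCCCn4cc(CNC(=O)CCCCC5CCSS5)nn4)cc3oc2=O)cc1`, gives 62% in this assay.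

Among the three measured compounds, compound 1 stands lowest; its nearest neighbour is compound 2 (a number 2.3 percentage points higher from compound 1 to compound 2 (within the scatter)), its furthest is compound 3 (a number 22.2 percentage points higher from compound 1 to compound 3 (beyond the scatter)). Compound 4, `O=C(CCCCC1CCSS1)NCc1cn(CCCOc2ccc3cc(-c4ccc(Cl)cc4)c(=O)oc3c2)nn1`, differs from compound 1 in one place: 4-chlorophenyl in place of acetyl on an aromatic carbon. The step that bears on this change is the one in which an aryl group replaced the acetyl, a number 22.2 percentage points higher from compound 1 to compound 3 (beyond the scatter); the parallel step a number 19.9 percentage points higher from compound 2 to compound 3 (beyond the scatter) points the same way. Since compound 4 carries 4-chlorophenyl rather than 4-methoxyphenyl, a rise of roughly that size in this assay is expected for compound 4, namely a number 18.2 percentage points higher from compound 1 to compound 4 (beyond the scatter). Compound 4 is therefore estimated at 58%, between 42% and 72%.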

Compound 4, a percentage reported as activity, at one concentration (the size of the read-out at that concentration, not a potency): 75.6%
Beside the measured number, compound 4's estimate is 17.6 percentage points below it; measured number outside the range, above it.
By their numbers in this assay, from the lowest: compounds 1 and 2 (each within the scatter of the next); then compound 3; then compound 4.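

The position tolerates more than one aryl group, and the substituent on that aryl ring also counts: in this assay, chloro in place of methoxy gives a number 13.6 percentage points higher from compound 3 to compound 4 (beyond the scatter). Replacing acetyl with 4-chlorophenyl gives a number 35.8 percentage points higher from compound 1 to compound 4 (beyond the scatter) and replacing ethoxycarbonyl with it gives a number 33.5 percentage points higher from compound 2 to compound 4 (beyond the scatter); both steps are large. Across these compounds, the aryl-bearing compound 3 and compound 4 both stand clear of compound 1 and compound 2.

No supporting evidence accounts for these differences. As far as these compounds go, whether an unsubstituted phenyl, a fluoro or an amine on the aryl ring would fall in line with these results remains open.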